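Swapping the ring on the oxygen: compound 3 to compound 4

This account rests on a few compounds, and the source may have more. Where it says the series, first, only, none or still open, it means among the compounds named here.

Compound 1 `Cc1ccc(Cn2c(Nc3ccc(OC(C)C)c(Cl)c3)nc(=O)n(CCC(=O)O)c2=O)cc1` gives 3.1 mg/kg
Compound 2 `C[C@@H](Cn1c(=O)[nH]/c(=N\c2ccc(Oc3ccccn3)cc2)n(Cc2ccc(Cl)cc2)c1=O)C(=O)O` gives 0.4 mg/kg
Compound 3 `C[C@@H](Cn1c(=O)[nH]/c(=N\c2ccc(Oc3ccnc(F)c3)cc2)n(Cc2ccc(Cl)cc2)c1=O)C(=O)O` gives 0.3 mg/kg

These numbers come from a functional assay on the whole organism with Rattus norvegicus as the target; on this read-out lower numbers stand for an effect already at smaller amounts and higher numbers for an effect only at larger amounts of compound. Compound 3 stands within the scatter of compound 2 and beyond the scatter of compound 1, whose number is higher. Compound 4 `C[C@@H](Cn1c(=O)[nH]/c(=N\c2ccc(Oc3ccsn3)cc2)n(Cc2ccc(Cl)cc2)c1=O)C(=O)O` carries 1,2-thiazol-3-yl in place of 2-fluoropyridin-4-yl on an oxygen on an aromatic ring. For the measured compounds named here, one measured step bears on this exchange, a 1.3-fold lower number from compound 2 to compound 3 (0.12 log units; within the scatter), and it changes the ring on that same oxygen. Going by the values given here, no measured compound has a five-membered ring there, so the expectation is loose. No change beyond the scatter is expected, and the estimated step is a 1.3-fold higher number from compound 3 to compound 4 (0.12 log units; within the scatter). Compound 4 is estimated at 0.4 mg/kg, within a range of 0.15 mg/kg to 1.2 mg/kg.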

Compound 4, dose for half-maximal effect: 0.4 mg/kg
The estimate for compound 4 equals the measured number at the digits printed; measured number inside the range.
By their numbers in this assay, from the lowest: compounds 3, 2 and 4 (each within the scatter of the next); then compound 1.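

In this assay, swapping the ring on an oxygen on an aromatic ring for a five-membered one, 1,2-thiazol-3-yl, gives a 1.3-fold higher number from compound 3 to compound 4 (0.12 log units; within the scatter) and no change at the digits printed from compound 2 to compound 4 (within the scatter). Both six-membered rings and this five-membered ring with 2 hetero atoms therefore stand within the scatter of one another at this place. No measurement at hand explains this result. Still open is whether a saturated ring such as piperidine on that oxygen, or an amine on the 1,2-thiazol-3-yl ring, would stay within the scatter of these compounds.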